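The source may hold more compounds than are shown below. What is called first, only, known or untested is meant among the compounds shown, and "the series" means these compounds.

Values in a functional assay on MCF-A cells (Homo sapiens) for cytotoxicity; on this read-out higher numbers stand for weaker inhibition of growth and lower numbers for stronger inhibition of growth:
- compound 1 `COc1ccc(C2=C(c3ccc(SC)cc3)CC3CCCN3C2=O)cc1C`: 400 nM
- compound 2 `CSc1ccc(C2=C(c3ccc(C)cc3)C(=O)N3CCCC3C2)cc1`: 600 nM

Compound 2 stands at 600 nM and compound 1 at 400 nM. These two numbers lie within the scatter of each other, so they mark a single level in this assay and not a ranking.

The next compound is compound 3 `CSc1ccc(C2=C(c3ccc(F)cc3)C(=O)N3CCCC3C2)cc1`, reached from compound 2 by fluoro in place of methyl on an aromatic carbon. In words, this is fluoro in place of methyl on an aromatic carbon, the same difference as 4-methylphenyl to 4-fluorophenyl.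

Among the compounds with values here, only one measured step bears on this change: a 1.5-fold higher number from compound 1 to compound 2 (0.18 log units; within the scatter). It concerns the same aryl group and stays within the scatter. Within the data shown here, no measured compound carries fluoro, so the direction of any shift cannot be read from the data. No step beyond the scatter is therefore expected in this assay. The expected step is a 1.2-fold higher number from compound 2 to compound 3 (0.07 log units; within the scatter). For compound 3 the estimated value is 700 nM, with an expected range of 250 nM to 2000 nM.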

Compound 3, concentration for 50% growth inhibition: 800 nM
Estimate against measurement, compound 3: 1.1-fold (0.06 log units) below; low and high end bracket the measured number.
By their numbers in this assay, from the lowest: compounds 1, 2 and 3 (each within the scatter of the next).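

In this assay fluoro in place of methyl on an aromatic carbon, para to a large group, gives a 1.3-fold higher number from compound 2 to compound 3 (0.12 log units; within the scatter) and thus extends the single level seen so far to a first halogen at this position. The wider change, with the whole aryl group exchanged, gives a 2.0-fold higher number from compound 1 to compound 3 (0.30 log units; within the scatter) and so also leaves the read-out within the scatter, which means that neither the exchange of methyl for fluoro nor the loss of the methoxy and methyl pair from this aryl group separates these compounds. No supporting data are available to explain this flat result.

Whether this position can shift the read-out beyond the scatter at all remains open, since the substituents shown are small and neutral, and an amine, a carboxylic acid or a longer chain there could behave differently. The methylthio group on the other aryl ring and the shared core are the same in all three compounds, so their contribution to growth inhibition cannot be judged from this set.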